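Notes on the amide-nitrogen substituent, compound 2 to compound 3

This account rests on a few compounds, and the source may have more. Where it says the series, first, only, none or still open, it means among the compounds named here.

Measured so far:
compound 1, `CC[C@H](C)[C@H](NC(=O)c1cccc(Cn2ccnc2)c1)C(=O)Nc1nccs1`, gives 42000 nM
compound 2, `CC[C@H](C)[C@H](NC(=O)c1cccc(Cn2ccnc2)c1)C(=O)NS(=O)(=O)c1ccccc1`, gives 18000 nM

In an assay on HEK293 cells for displacement of a labelled ligand from Type-2 angiotensin II receptor (Homo sapiens) (on this read-out lower numbers stand for stronger inhibition and higher numbers for weaker inhibition), compound 2 stands at the lower of the two numbers measured, compound 1 being the only comparator. For the measured compounds named here, the single measured step, a 2.3-fold lower number from compound 1 to compound 2 (0.37 log units; beyond the scatter), shows that exchanging the group on the amide-type nitrogen shifts the number modestly, beyond the scatter.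

Compound 3, `CCCCCS(=O)(=O)NNC(=O)[C@@H](NC(=O)c1cccc(Cn2ccnc2)c1)[C@@H](C)CC`, carries the change ((pentylsulfonyl)amino in place of phenylsulfonyl on an amide-type nitrogen). Going by the values given here, no measured pair covers this particular exchange; the one step in hand says only that the amide-type nitrogen tolerates a different substituent with a modest movement in the number. For compound 3 a step of about that size in either direction, or none beyond the scatter, is expected, as a 1.2-fold lower number from compound 2 to compound 3 (0.08 log units; within the scatter). Compound 3 is therefore estimated at 15000 nM in this assay, with a range from 4000 nM to 50000 nM.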

Compound 3, inhibition constant: > 100000 nM
Compound 3 gave a limit, no number (the forecaster's own chance of this, stated with the estimate: 15%); middle value at least 6.6-fold (0.82 log units) away from the limit.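

Compound 3 gives only a limit of the read-out, not a number, in this assay: the limit of > 100000 nM in this assay, at which 1 of the 3 values shown sits.

The exchange of phenylsulfonyl for (pentylsulfonyl)amino on the amide-type nitrogen gives an at least 5.5-fold higher number from compound 2 to compound 3 (0.74 log units; beyond the scatter), opposite in direction to a 2.3-fold lower number from compound 1 to compound 2 (0.37 log units; beyond the scatter), so this position does not accept every substituent with only a modest movement. The same group also gives an at least 2.3-fold higher number from compound 1 to compound 3 (0.37 log units; beyond the scatter), which places compound 3 on the weaker side of both earlier compounds.

On these data alone, it remains open whether the change in the number follows from the pentyl chain replacing the phenyl ring or from the added amino nitrogen with its hydrogen-bond donor. A (phenylsulfonyl)amino group or a pentylsulfonyl group on the amide-type nitrogen would separate these two parts of the exchange.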